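The source may report more compounds than this note shows. Statements on the series, on what has been measured and on what is new or still open speak of the compounds shown alone.

Compound 1 `CCCCCCCCC#Cc1cn(CCC(COC(C)=O)COC(C)=O)c(=O)n(C(=O)c2ccccc2)c1=O` carries a saturated chain that ends in a triple bond attached to its core. In a functional assay on SW-620 cells (Homo sapiens) for antiproliferative activity, read by MTT assay, with a stated time of 72 h (on this read-out lower numbers stand for stronger inhibition and higher numbers for weaker inhibition), compound 1 gives 65800 nM. Compound 2 `CC(=O)OCC(CCn1cc(C#CCCCCl)c(=O)n(C(=O)c2ccccc2)c1=O)COC(C)=O` keeps that core but carries chloro in place of pentyl on a saturated chain carbon, three bonds along the chain from a triple-bonded carbon. In this assay compound 2 gives only a limit of the assay, > 100000 nM. That change brought an at least 1.5-fold higher number from compound 1 to compound 2 (0.18 log units; that floor lies within the scatter). Compound 3 `CCCCCCCCC#Cc1cn(CCC(CO)CO)c(=O)[nH]c1=O` rests on a different core; how the two cores differ is not broken down here. In this assay compound 3 also gives only a limit, > 100000 nM. The picture is thus dominated by the limit of > 100000 nM in this assay, at which 2 of the 3 values shown sit. Compound 4 `O=c1[nH]c(=O)n(CCC(CO)CO)cc1C#CCCCCl` is made from compound 3 by the same change, (chloro in place of pentyl on a saturated chain carbon, three bonds along the chain from a triple-bonded carbon), at the same place. The step from compound 3 to compound 4 is expected to be a step that the limit leaves unreadable from compound 3 to compound 4, resting on (the limit of > 100000 nM in this assay, at which 2 of the 3 values shown sit). Compound 4 is therefore expected to give about 150000 nM, between 100000 nM and 300000 nM.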

Compound 4, half-maximal inhibitory concentration: > 100000 nM
Compound 4: only a limit was reported; the forecaster's own chance of this, stated with the estimate: 85%; the middle value does not contradict the limit.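

In this assay compound 3 and compound 4 each give only a limit of the assay, so no step can be read between them. The compounds shown leave open whether chloro in place of pentyl changes antiproliferative activity at all.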